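A Methoxyethyl Amide in Place of Methyl(phenyl)amino

The compounds below may be only part of what the source reports. "The series", "measured", "known", "first", "only" and "open" are said of these compounds alone.

Measured so far:
compound 1, `CN(c1ccccc1)c1cnc(NCc2c(F)ccc3c2CCO3)n2cnnc12`, with 3.6;
compound 2, `CN(C)Cc1ccc2c(c1)CN(c1cnc(NCc3c(F)ccc4c3CCO4)c3cn[nH]c(=O)c13)C2=O`, with 2.2.

Both numbers come from a physicochemical assay for lipophilicity, using the shake flask method, in phosphate buffer, measured as octanol-water partition, with a stated time of 30 min, at pH 7.4; on this read-out lower numbers stand for lower lipophilicity and higher numbers for higher lipophilicity. Among the two values in hand, compound 1 stands highest, and compound 2 lies well below it, a gap that is beyond the usual scatter of this assay. The two compounds share no single point of difference, so their values are simply two separate readings rather than a step that can be traced to one change.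

The unmeasured compound 3, `COCCC(=O)Nc1cnc(NCc2c(F)ccc3c2CCO3)n2cnnc12`, is compound 1 with one part exchanged: ((2-methoxyethyl)carbonyl)amino in place of methyl(phenyl)amino on an aromatic carbon. A six-membered aromatic ring of carbon only leaves, and a chain with one hydrogen-bond donor and two hydrogen-bond acceptors enters on the same aromatic carbon of the shared core.

Starting from compound 1 at 3.6, a downward step in this assay is expected, and a large one, a number 2.20 log units lower from compound 1 to compound 3 (beyond the scatter), well beyond the scatter. Compound 3 is therefore estimated at 1.4, with a likely range from 0.7 to 2.1.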

Compound 3, distribution coefficient: 1.4
Compound 3: middle estimate and measured number agree at the digits printed; measured number inside the range.
By their numbers in this assay, from the lowest: compound 3; then compound 2; then compound 1.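

Going by these compounds alone, on this aromatic carbon, the exchange of methyl(phenyl)amino for ((2-methoxyethyl)carbonyl)amino gives, in this assay, a number 2.20 log units lower from compound 1 to compound 3 (beyond the scatter) and provides the first change here that can be traced to a single place, which compound 1 and compound 2 could not offer. With the rest of the molecule the same, the size of this step shows that the read-out depends strongly on what occupies this position. Several things change together, with a six-membered aromatic ring of carbon only leaving, a chain with no ring entering, and the counts of hydrogen-bond donors and acceptors both rising, yet no separate measurement shows how the step divides among these differences or why it occurs.

The compounds shown leave open whether the ring, the amide or the methoxyethyl end matters most: an acetylamino group would remove the methoxy end, while a benzoylamino group would combine the amide with a six-membered aromatic ring. A longer chain or a chain ending in an amine or a carboxylic acid at this position also remains to be compared.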